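Uracil-linked aryl ethers in a cell tolerance test

The compounds below may be only part of what the source reports. "The series", "measured", "known", "first", "only" and "open" are said of these compounds alone.

Compound 1 `Nc1ccc(OCCCCCn2ccc(=O)[nH]c2=O)cc1` gives > 100000 nM in an ADME assay on HEL cells (Homo sapiens) for cytotoxicity, read by microscopy (a higher number here means that more compound is tolerated, a lower number that less compound is tolerated), a limit rather than a number.
Compound 2 `O=c1ccn(CCCCCOc2ccc(Cl)cc2)c(=O)[nH]1` gives > 100000 nM in this assay, likewise a limit.

Compound 2 thus stands at the limit of this assay, as does compound 1; the step that the two limits leave unreadable from compound 1 to compound 2 cannot be read in size. Compound 3 `Cc1ccccc1OCCCCCn1ccc(=O)[nH]c1=O` differs from compound 2 by 2-methylphenyl in place of 4-chlorophenyl on an oxygen on a saturated carbon. Among the compounds with values here, no measured step shows a readable size, so no shift beyond the scatter is expected, and compound 3 is estimated at 100000 nM (range 50000 nM to 200000 nM), an expected step of a number no higher from compound 2 to compound 3 (the limit leaves the size open), most likely again reported only as a limit.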

Compound 3, minimum cytotoxic concentration: > 100000 nM
Compound 3: no number, only a limit (the forecaster's own chance of this, stated with the estimate: 85%); the middle value lies on the limit itself.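

The steps among compound 1, compound 2 and compound 3 cannot be read, as all three give only a limit in this assay: the limit of > 100000 nM in this assay, at which 3 of the 3 values shown sit.

The compounds shown leave open where each true value lies and whether the three differ at all.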